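The compounds below may be only part of what the source reports. "The series", "measured", "known", "first", "only" and "open" are said of these compounds alone.

Among the measured compounds shown here, compound 2 `COc1cc(F)c(NC(=O)c2ccccn2)cc1Nc1nccc(-c2cn(C)c3ccccc23)n1` is one of two compounds measured in a functional assay on A549 cells (Homo sapiens) for antiproliferative activity, read by MTT assay, with a stated time of 72 h (on this read-out higher numbers stand for weaker inhibition and lower numbers for stronger inhibition), and, in that assay, compound 2 gives 7980 nM. For the measured compounds named here, its only measured neighbour is compound 1 `COc1cc(F)c(NC(=O)c2ccncc2)cc1Nc1nccc(-c2cn(C)c3ccccc23)n1`, which in this assay gives 4200 nM; the two values lie within the scatter of each other, so neither number can be set apart from the other. Going by the values given here, the one measured step, a 1.9-fold higher number from compound 1 to compound 2 (0.28 log units; within the scatter), is thus a change at the carbonyl carbon that did not move the read-out beyond the scatter.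

Compound 3 `COc1cc(F)c(NC(=O)c2cnccn2)cc1Nc1nccc(-c2cn(C)c3ccccc23)n1` has not yet been measured. It differs from compound 2 by pyrazin-2-yl in place of pyridin-2-yl on a carbonyl carbon. Among the compounds with values here, this is again a swap of one six-membered aromatic ring for another at the same carbonyl carbon, and the only step that bears on such a swap, a 1.9-fold higher number from compound 1 to compound 2 (0.28 log units; within the scatter), stayed within the scatter. On that single precedent a step of a 1.1-fold lower number from compound 2 to compound 3 (0.06 log units; within the scatter) is expected, that is, none beyond the scatter. Compound 3 is therefore estimated at 7000 nM in this assay, with a range from 3000 nM to 16000 nM.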

Compound 3, half-maximal inhibitory concentration: 2490 nM
Beside the measured number, compound 3's estimate is 2.8-fold (0.45 log units) above it; the measured number lies below the stated range.
By their numbers in this assay, from the lowest: compounds 3, 1 and 2 (each within the scatter of the next, the first and the last beyond it).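

At this carbonyl carbon, in this assay, a swap of one six-membered aromatic ring for another can move the read-out beyond the scatter: pyrazin-2-yl in place of pyridin-2-yl gives a 3.2-fold lower number from compound 2 to compound 3 (0.51 log units; beyond the scatter), a modest step, where the earlier exchange of pyridin-4-yl for pyridin-2-yl did not leave the scatter. The result depends on which ring is the point of comparison, since pyrazin-2-yl in place of pyridin-4-yl gives a 1.7-fold lower number from compound 1 to compound 3 (0.23 log units; within the scatter), which stays within the scatter, so pyrazin-2-yl is set apart from pyridin-2-yl only. The entering ring carries 2 hetero atoms where the leaving ring carries 1, but nothing measured here accounts for the step.

The compounds shown leave open whether this position tolerates anything other than these aromatic rings, such as an amine or a longer chain on the carbonyl carbon. They also leave open whether the step from pyridin-2-yl to pyrazin-2-yl would hold on any other core or in any other cell line, since all three compounds share one core and one read-out.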